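Ester variation on a shared dihydropyrimidine-type series

A few compounds are considered here, and "the series" means these few. Any claim that something is new, unique, unknown or untested is made for them only; others in the source may bear on it.

Measured so far, in an assay on membranes from HEK293 cells for displacement of a labelled ligand from adenosine receptor A2b (Homo sapiens), read by scintillation counting, with a stated time of 30 min, tested at 1 uM; a higher number here means more inhibition at the concentration tested (going by the name of the read-out), a lower number less inhibition:
- compound 2 `CCCOC(=O)C1=C(C)NC(=S)NC1c1ccco1` gives 46%
- compound 1 `CC1=C(C(=O)OC(C)(C)C)C(c2cccs2)NC(=O)N1` gives 38%

Compound 2 and compound 1 give numbers that lie within the scatter of each other, so neither can be placed above the other; both show partial inhibition at the tested concentration. Within the data shown here, no pair differing in a single place has been measured, so nothing is yet known about how any one change moves this assay.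

Compound 3 `CC1=C(C(=O)OCc2ccccc2)C(c2ccco2)NC(=S)N1` is the next point. Relative to compound 2 the change is phenyl in place of ethyl on a saturated chain carbon bound to an oxygen next to a carbonyl group. The rest of the structure is unchanged.

Among the measured compounds shown here, no measured step covers a change of this kind, so the expectation for the step from compound 2 to compound 3 is no move beyond the scatter, with a number 1 percentage points lower from compound 2 to compound 3 (within the scatter) expected. For compound 3 the estimate is 45%, expected to fall between 25% and 65%.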

Compound 3, a percentage reported as inhibition, at one concentration (the size of the read-out at that concentration, not a potency): 41%
Estimate against measurement, compound 3: 4 percentage points above; the range from low to high includes it.
By their numbers in this assay, from the lowest: compounds 1, 3 and 2 (each within the scatter of the next).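

Phenyl in place of ethyl on a saturated chain carbon bound to an oxygen next to a carbonyl group, which also reads as propyl to benzyl, gives a number 5 percentage points lower from compound 2 to compound 3 (within the scatter) in this assay. Among these compounds, this is the first single-place comparison, and it shows that this position can carry a six-membered aromatic ring of carbon only without a change that can be read in this assay. Nothing available bears on the reason for this result.

Going by these compounds, whether a carboxylic acid, an amine or a longer chain at this place would give a step beyond the scatter remains open. Also open, on these data alone, is how a change elsewhere would act, since compound 2 and compound 3 share the rest of their structure.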